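The source may hold more compounds than are shown below. What is called first, only, known or untested is meant among the compounds shown, and "the series" means these compounds.

Measured so far in a physicochemical assay for lipophilicity; on this read-out higher numbers stand for higher lipophilicity and lower numbers for lower lipophilicity:
- compound 1 `CN1CCN(c2cc(C(F)(F)F)ccc2[C@H]2CCOc3cc(S(=O)(=O)Nc4nccs4)ccc32)CC1`: 2.1
- compound 2 `Cc1nc(-c2cc(C(F)(F)F)ccc2[C@H]2CCOc3cc(S(=O)(=O)Nc4ncc(F)cn4)ccc32)co1`: 2.8

Compound 1 holds the lower of these two numbers, and compound 2 sits above it by more than the usual scatter of repeat measurements. Compound 3 `O=C1OCCN1c1cc(C(F)(F)F)ccc1[C@H]1CCOc2cc(S(=O)(=O)Nc3nccs3)ccc21` has not been measured yet. It differs from compound 1 in one place: 2-oxo-1,3-oxazolidin-3-yl in place of 4-methylpiperazin-1-yl on an aromatic carbon, with 2-oxo-1,3-oxazolidin-3-yl in place of 4-methylpiperazin-1-yl on an aromatic carbon. For the measured compounds named here, no measured pair differs in one place only, so the expectation is tentative: no shift beyond the scatter in this assay. The expected step is a number 0.10 log units higher from compound 1 to compound 3 (within the scatter). For compound 3 the estimate is 2.2, within an expected range of 1.6 to 2.8.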

Compound 3, distribution coefficient: 2.1
Estimate against measurement, compound 3: 0.10 log units above; the range from low to high includes it.
By their numbers in this assay, from the lowest: compounds 1 and 3 (each within the scatter of the next); then compound 2.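

In this assay, 2-oxo-1,3-oxazolidin-3-yl in place of 4-methylpiperazin-1-yl gives no change at the digits printed from compound 1 to compound 3 (within the scatter). On this aromatic carbon, ortho to a large group and meta to a trifluoromethyl group, a five-membered ring with a carbonyl therefore reads the same as a six-membered ring with two nitrogens, despite their different atoms. Nothing available explains this match. On these data alone, whether an open-chain amine or a carboxylic acid on this carbon would also leave the number unchanged stays open. So does whether the same swap would give a similar step in the setting of compound 2.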